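A few compounds are considered here, and "the series" means these few. Any claim that something is new, unique, unknown or untested is made for them only; others in the source may bear on it.

Of the compounds shown here, three have been measured in a toxicity assay on THP-1 cells (Homo sapiens) for inhibition; on this read-out lower numbers stand for higher toxicity in this test and higher numbers for lower toxicity in this test. Compound 1 `Cn1c(-c2ccccc2Cl)cnc1NC(=O)c1ncc[nH]1` stands at a limit of that assay, giving > 50000 nM in this assay. Compound 2 `Cn1c(-c2ccccc2Cl)cnc1NC(=O)c1ccc(F)cc1` likewise stands at a limit, giving > 50000 nM in this assay. Compound 3 `Cc1ccc(C(=O)Nc2ncc(-c3ccccc3)o2)cc1` gives a number, 26000 nM in this assay. The change from compound 1 to compound 2 puts 4-fluorophenyl in place of 1H-imidazol-2-yl on a carbonyl carbon, yet a step that the two limits leave unreadable from compound 1 to compound 2. So compound 2 is known only as a limit, and the limit of > 50000 nM in this assay, at which 2 of the 3 values shown sit, marks where it sits.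

Compound 4 `COc1ccccc1-c1cnc(NC(=O)c2ccc(F)cc2)n1C` has not been measured. Its difference from compound 2 is methoxy in place of chloro on an aromatic carbon: methoxy replaces chloro on an aromatic carbon of a six-membered aromatic ring of carbon only, ortho to a large group, which cut one bond further out reads 2-chlorophenyl to 2-methoxyphenyl. Going by the values given here, no measured step involves this change, and the single measured step cannot be read, so no size or direction can be expected beyond the scatter. The step from compound 2 to compound 4 is estimated as a number no higher from compound 2 to compound 4 (the limit leaves the size open). The estimate for compound 4 is 50000 nM, within a range from 20000 nM to 120000 nM.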

Compound 4, half-maximal cytotoxic concentration: > 100000 nM
Compound 4: no number, only a limit; the forecaster's own chance of this, stated with the estimate: 70%; middle value at least 2.0-fold (0.30 log units) from the limit.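

In this assay compound 2 gives only a limit (> 50000 nM) and no number. Compound 4 likewise gives only a limit (> 100000 nM). The step between these two compounds therefore cannot be read. From the compounds shown here alone, whether 2-methoxyphenyl in place of 2-chlorophenyl changes the read-out at all, and in which direction, stays open.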